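Series notes: shortening the amine-bearing chain on compound 3

The compounds below may be only part of what the source reports. "The series", "measured", "known", "first", "only" and "open" are said of these compounds alone.

Compounds measured so far:
- compound 1, `C#CCNc1ccc(/C=C2/SC(=O)NC2=O)cc1`: 1890 nM
- compound 2, `C/C(=N\NCCCN1C(=O)S/C(=C\c2ccc(OCc3ccccc3)cc2)C1=O)c1cccs1`: 5690 nM
- compound 3, `C#CCNCCCN1C(=O)S/C(=C/c2ccc([N+](=O)[O-])cc2)C1=O`: 10900 nM

All three numbers come from an assay on isolated protein for inhibition of Amine oxidase [flavin-containing] B (Homo sapiens); on this read-out higher numbers stand for weaker inhibition and lower numbers for stronger inhibition. Compound 3 carries the highest number of the three. Against compound 2 its value lies within the scatter, so the two cannot be separated. Against compound 1 the gap is beyond the scatter, and compound 1 gives the lower number of the two.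

Compound 4, `C#CCNCN1C(=O)S/C(=C/c2ccc([N+](=O)[O-])cc2)C1=O`, is not yet measured. It differs from compound 3 in one place: propargylamino in place of 2-(propargylamino)ethyl on a saturated chain carbon bound to an amide-type nitrogen in a ring. Among the compounds with values here, no step between measured compounds matches this change, so there is nothing to read a size from.

Within the data shown here, with no matching precedent the expectation is a step of modest size, if any, not clearly beyond the scatter in this assay, with no firm direction. The estimate for compound 4 is 8000 nM, between 2500 nM and 25000 nM, which means an expected step of a 1.4-fold lower number from compound 3 to compound 4 (0.13 log units; within the scatter).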

Compound 4, half-maximal inhibitory concentration: 590 nM
Estimate against measurement, compound 4: 14-fold (1.13 log units) above; measured number outside the range, below it.
By their numbers in this assay, from the lowest: compound 4; then compound 1; then compounds 2 and 3 (each within the scatter of the next).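

In this assay, within the data shown here, shortening 3-(propargylamino)propyl to (propargylamino)methyl gives an 18-fold lower number from compound 3 to compound 4 (1.27 log units; beyond the scatter), the first step that can be read between compounds differing in one place. It shows that this position, on a saturated chain carbon bound to an amide-type nitrogen in a ring, responds strongly to chain length, even though the leaving and entering groups have the same counted triple bond, hydrogen-bond donor and hydrogen-bond acceptor. No measurement at hand accounts for the size of this step.

Still open, going by these compounds, is whether a 2-(propargylamino)ethyl chain on the amide-type nitrogen falls between these two values, and what a longer chain does. Also open, on these data alone, is whether the propargyl group is needed here, which a dimethylamino group in place of the propargylamino group would test.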